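Adding hydroxy to the most active ether

The source may hold more compounds than are shown below. What is called first, only, known or untested is meant among the compounds shown, and "the series" means these compounds.

compound 1 `O=c1c(Cc2coc3cccc(OCC4CCCCC4)c3c2=O)coc2ccccc12`: 3530 nM
compound 2 `CC(C)COc1cccc2occ(Cc3coc4ccccc4c3=O)c(=O)c12`: > 10000 nM (a limit)
compound 3 `CC(C)CCOc1cccc2occ(Cc3coc4ccccc4c3=O)c(=O)c12`: > 10000 nM (a limit)

Going by the values given here, in a functional assay on NUGC-3 cells (Homo sapiens) for antiproliferative activity, read by XTT assay (on this read-out higher numbers stand for weaker inhibition and lower numbers for stronger inhibition), compound 1 gives 3530 nM, the only number among the three. Compound 2 and compound 3 report limits only.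

Compound 4 `O=c1c(Cc2coc3cccc(OCC4CCCCC4)c3c2=O)coc2cc(O)ccc12` differs from compound 1 by hydroxy in place of hydrogen on an aromatic carbon.

Replacing cyclohexyl gave an at least 2.8-fold higher number from compound 1 to compound 2 (0.45 log units; beyond the scatter) with isopropyl and an at least 2.8-fold higher number from compound 1 to compound 3 (0.45 log units; beyond the scatter) with isobutyl. Compound 4 keeps the cyclohexyl, so neither step sizes this change. From the compounds shown here alone, no step beyond the scatter is expected in this assay, and the direction stays open.

The expected change is a 1.2-fold lower number from compound 1 to compound 4 (0.07 log units; within the scatter). For compound 4 the estimate is 3000 nM, with an expected range of 900 nM to 10000 nM.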

Compound 4, half-maximal inhibitory concentration: 3220 nM
Compound 4: the middle estimate sits 1.1-fold (0.03 log units) below what was measured, within the range that was stated.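

In this assay, hydroxy in place of hydrogen on an aromatic carbon, meta to a fused ring and para to a fused ring, gives a 1.1-fold lower number from compound 1 to compound 4 (0.04 log units; within the scatter). Going by these compounds alone, with the cyclohexyl kept, this position therefore accepts a hydroxy without a change beyond the scatter, whereas the earlier steps, at the cyclohexyl, went beyond it.

From the compounds shown here alone, whether a methoxy, an amine or a carboxylic acid at this position would behave alike stays open. Also open is what the same hydroxy does on compound 2 and compound 3, which report only a limit: the limit of > 10000 nM in this assay, at which 2 of the 4 values shown sit.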